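Trimming a Hexylamino Chain to Ethylamino

The compounds below may be only part of what the source reports. "The series", "measured", "known", "first", "only" and "open" are said of these compounds alone.

Of the compounds shown here, three sharing one core have been measured in a functional assay on EL4 cells (Mus musculus) for inhibition, tested at 100 uM; a lower number here means less inhibition, a higher number more inhibition at the concentration tested (going by the name of the read-out). Compound 1 `CN(C)c1nccc2c1ncn2C1O[C@H](CO)[C@@H](O)[C@H]1O` gives 10%. Compound 2 `CNc1nccc2c1ncn2C1O[C@H](CO)[C@@H](O)[C@H]1O` gives 11%. Compound 3 `CCCCCCNc1nccc2c1ncn2C1O[C@H](CO)[C@@H](O)[C@H]1O` gives 14%. Compound 3 holds the highest of the three numbers, yet its distance to both others is small: the step of a number 4 percentage points higher from compound 1 to compound 3 (within the scatter) and the step of a number 3 percentage points higher from compound 2 to compound 3 (within the scatter) sit inside the usual scatter, so on these numbers the three compounds cannot be told apart.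

Compound 4 `CCNc1nccc2c1ncn2C1O[C@H](CO)[C@@H](O)[C@H]1O` has not yet been measured. It differs from compound 3 by hydrogen in place of butyl on a saturated chain carbon, two bonds along the chain from a nitrogen on an aromatic ring. Two measured steps alter the same chain and so bear on this change: the step of a number 3 percentage points higher from compound 2 to compound 3 (within the scatter), where pentyl enters in place of hydrogen, and the step of a number 4 percentage points higher from compound 1 to compound 3 (within the scatter), where the whole hexylamino group replaces dimethylamino. The step of a number 1 percentage points higher from compound 1 to compound 2 (within the scatter), which changes the group on the same nitrogen, also stays within scatter. Lengthening or reshaping this chain has therefore not moved the read-out beyond scatter in any measured pair, and shortening it is expected to behave alike.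

For compound 4 the expected step is a number 2 percentage points lower from compound 3 to compound 4 (within the scatter), meaning no change beyond scatter. Compound 4 is therefore estimated at 12%, with a range from 4% to 21%.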

Compound 4, a percentage reported as inhibition, at one concentration (the size of the read-out at that concentration, not a potency): 8%
Estimate against measurement, compound 4: 4 percentage points above; measured number inside the range.
By their numbers in this assay, from the lowest: compounds 4, 1, 2 and 3 (each within the scatter of the next).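

With the chain cut back to ethyl, the change at this saturated chain carbon, two bonds along the chain from a nitrogen on an aromatic ring, can now be read directly in this assay (a number 6 percentage points lower from compound 3 to compound 4 (within the scatter)). This is the widest step among the four compounds, yet removing butyl still does not separate compound 4 from compound 3, so hexylamino and ethylamino cannot be told apart here. The ethylamino group also matches the smaller groups on that nitrogen, with a number 3 percentage points lower from compound 2 to compound 4 (within the scatter) and a number 2 percentage points lower from compound 1 to compound 4 (within the scatter), and no further measurement bears on this result.

The compounds shown carry only plain alkyl groups on this nitrogen, so it stays open whether a chain ending in an amine or a carboxylic acid, or a phenyl ring in place of the chain, would move the read-out beyond the scatter. Also open, from the compounds shown here alone, is how these four compounds compare in potency, since a read-out at one concentration gives only the size of the inhibition at that concentration.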